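Naphthyl Urea on a Carbamoyl Core: Expected Potency

The compounds below may be only part of what the source reports. "The series", "measured", "known", "first", "only" and "open" are said of these compounds alone.

Compound 1 `O=C(Nc1ccccc1F)N1c2ccnn2CC1c1ccccc1` gives 5.4 nM in a functional assay on cells (Neutrophil, Homo sapiens) for inhibition, with a stated time of 10 min; on this read-out higher numbers stand for weaker inhibition and lower numbers for stronger inhibition. Compound 2 `NC(=O)c1cnn2c1N(C(=O)Nc1ccccc1F)C(c1ccccc1)C2` gives only the limit > 1000 nM in this assay.

Compound 2 thus stands at the limit of > 1000 nM in this assay, at which 1 of the 2 values shown sits, so no number is known for it. For the measured compounds named here, the one measured step, an at least 180-fold higher number from compound 1 to compound 2 (2.26 log units; beyond the scatter), concerns the carbamoyl group, which compound 3 `NC(=O)c1cnn2c1N(C(=O)Nc1cccc3ccccc13)C(c1ccccc1)C2` keeps; compound 3 differs from compound 2 by naphthalen-1-yl in place of 2-fluorophenyl on an amide-type nitrogen. Going by the values given here, no measured step bears on this exchange of aryl groups, so no change beyond the scatter is expected, and compound 3 is expected to stay at the limit. Compound 3 is estimated at 2000 nM, within 500 nM to 10000 nM, an expected step that the limit leaves unreadable from compound 2 to compound 3.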

Compound 3, half-maximal inhibitory concentration: 110 nM
For compound 3 the middle estimate is 18-fold (1.26 log units) above the measured one; the whole stated range lies above it.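

The aryl group on the amide-type nitrogen matters even with the carbamoyl group in place: in this assay, naphthalen-1-yl in place of 2-fluorophenyl gives an at least 9.0-fold lower number from compound 2 to compound 3 (0.95 log units; beyond the scatter). Compound 1 and compound 2 both carry 2-fluorophenyl, so neither could show this. From the compounds shown here alone, the true size of the step stays unknown, since the value of compound 2 is only a limit: the limit of > 1000 nM in this assay, at which 1 of the 3 values shown sits.

Going by these compounds, it remains open whether naphthalen-1-yl would have the same effect without the carbamoyl group. Also open, on these data alone, is how naphthalen-2-yl at this nitrogen, or a carboxylic acid in place of the carbamoyl group, would read in this assay.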